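The compounds below may be only part of what the source reports. "The series", "measured", "known", "first", "only" and "open" are said of these compounds alone.

Compound 3, whose structure is `CO[C@@H]1O[C@H](COc2cccc(C(C)C)c2)[C@@H](O)[C@H](O)[C@H]1Oc1ccc(OC2CCCCC2)cc1`, was tested in a functional assay on MDA-MB-231 cells (Homo sapiens) for cytotoxicity, read by MTT assay, with a stated time of 48 h; a higher number here means that more compound is needed for the effect, a lower number that less compound is needed. In this assay compound 3 gives 40000 nM. Two companions share the same core with different groups attached. Compound 2, with the structure `CO[C@H]1O[C@H](COc2ccc3c(c2)CCCC3)[C@@H](O)[C@H](O)[C@H]1Oc1ccc(OC2CCCCC2)cc1`, gives 20000 nM in this assay. The numbers for compound 2 and compound 3 lie within the usual scatter of each other, so the gap between them carries no meaning. Compound 1, with the structure `CO[C@H]1O[C@H](COc2cccc3c2CCCC3)[C@@H](O)[C@H](O)[C@H]1Oc1ccc(OC2CCCCC2)cc1`, has no result in this assay; its entry reads "not determined" (no result reported). For the measured compounds named here, compound 3 therefore holds the higher of only two numbers, and even that by a margin inside the scatter.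

The next compound is compound 4, with the structure `CO[C@H]1O[C@H](COc2cccc(C(C)C)c2)[C@@H](O)[C@H](O)[C@H]1Oc1ccc(OC2CCCCC2)cc1`. How it differs from compound 3: the two compounds have the same atoms and bonds and differ only in configuration as drawn: 1 of 5 stereo elements differ; a stereocentre at a saturated ring carbon is drawn R in compound 3 and S in compound 4. Going by the values given here, no measured pair in this set differs only in configuration, so there is no earlier step of this kind to lean on. Since nothing enters and nothing leaves, the change is expected to give a step that stays within the scatter, in no particular direction. The value expected for compound 4 in this assay is 30000 nM, with a range from 10000 nM to 90000 nM. That estimate implies an expected step of a 1.3-fold lower number from compound 3 to compound 4 (0.12 log units; within the scatter).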

Compound 4, half-maximal effective concentration: 38000 nM
For compound 4 the middle estimate is 1.3-fold (0.10 log units) below the measured one, within the range that was stated.
By their numbers in this assay, from the lowest: compounds 2, 4 and 3 (each within the scatter of the next).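

In this assay, the stereocentre at a saturated ring carbon, drawn R in compound 3 and S in compound 4, gives a 1.1-fold lower number from compound 3 to compound 4 (0.02 log units; within the scatter) and so has no readable effect on the number in this pair. For the compounds shown here, this is the first comparison in the set that tests configuration alone, and it can be read cleanly because no other structural difference can contribute to the step: the fact that compounds 3 and 4 differ only in the configuration as drawn.

The set also gains its first step across a single changed group, 3-isopropylphenyl in place of 1,2,3,4-tetrahydronaphthalen-6-yl on an oxygen on a saturated carbon, which gives a 1.9-fold higher number from compound 2 to compound 4 (0.28 log units; within the scatter) and likewise shows no readable effect.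

Still open, on these data alone, is whether an amine or a carboxylic acid in place of the isopropyl group would carry the number beyond the scatter. It is equally open whether the same stereocentre would make a readable difference with 1,2,3,4-tetrahydronaphthalen-6-yl in place of 3-isopropylphenyl, as only one pair of this kind is shown.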